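The compounds below may be only part of what the source reports. "The series", "measured", "known", "first", "only" and "open" are said of these compounds alone.

Working notes on a small set of thioacetamide-linked compounds sharing one core.

Among the measured compounds shown here, compound 1 `Cc1nc(SCC(=O)Nc2nc(-c3ccc(Cl)cc3)cs2)n(Nc2ccccc2)c1C` and compound 2 `Cc1ccc(Nn2c(SCC(=O)Nc3nc(-c4ccccc4)cs3)nc(C)c2C)cc1` are the two members with numbers so far. In a functional assay on MDA-MB-468 cells (Homo sapiens) for antiproliferative activity, read by sulforhodamine B assay, with a stated time of 48 h (a lower number here means a stronger inhibitor of growth, a higher number a weaker inhibitor of growth), compound 1 gives 1450 nM, and in this assay compound 2 gives 1700 nM; these two values fall within the scatter of each other, so neither compound can be ranked against the other, and compound 2 differs from compound 1 in more than one place, which rules out reading a single-step effect from the pair.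

Compound 3 `COc1ccc(Nn2c(SCC(=O)Nc3nc(-c4ccc(Cl)cc4)cs3)nc(C)c2C)cc1` has not yet been measured. Relative to compound 1 the change is methoxy in place of hydrogen on an aromatic carbon. For the measured compounds named here, no measured pair in the set isolates this change, so there is no step to lean on, and the only guide is that compound 2, with its own ring substitution, sits within scatter of compound 1.

On that basis the expected step from compound 1 to compound 3 in this assay is a 1.0-fold higher number from compound 1 to compound 3 (0.01 log units; within the scatter), that is, no change beyond the scatter. The estimate for compound 3 in this assay is 1500 nM, with a range from 600 nM to 4000 nM.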

Compound 3, concentration for 50% growth inhibition: 570 nM
Compound 3: the middle estimate sits 2.6-fold (0.42 log units) above what was measured; measured number below the stated range.
By their numbers in this assay, from the lowest: compound 3; then compounds 1 and 2 (each within the scatter of the next).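

Methoxy in place of hydrogen on an aromatic carbon of the anilino ring, para to a large group, gives the first step in this set that can be read from a single change: a 2.5-fold lower number from compound 1 to compound 3 (0.41 log units; beyond the scatter) in this assay. Until now the set could not show whether this position responds to substitution at all, since compound 1 and compound 2 differ in more than one place; the pair of compound 1 and compound 3 shows that it does, and that the phenyl to 4-methoxyphenyl change moves the number down, though the step is modest and rests on this one pair. Nothing available here bears on the reason for this step.

On these data alone, what remains open is whether the step belongs to methoxy itself or would also appear with another group at the same place, such as a hydroxyl, a fluorine, a dimethylamino group or a longer ethoxy chain. As far as these compounds go, it is also open whether methoxy at another carbon of this ring would give a similar step, and whether the step carries over to a compound without the chlorine on the other aromatic ring.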